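The compounds below may be only part of what the source reports. "The series", "measured", "known", "first", "only" and "open" are said of these compounds alone.

Compound 1 `COC(=O)/C=C/c1cccc(N(Cc2ccc(Br)cc2)C(=O)C2CCCCC2)c1` was tested in an assay on isolated protein with Bile acid receptor (Homo sapiens) as the target; a lower number here means that less compound is needed, a higher number that more compound is needed for the effect. In this assay compound 1 gives only a limit, > 1000 nM. Compound 2 `CCOC(=O)/C=C/c1ccc(CN(C(=O)C2CCCCC2)c2cccc(/C=C/C(=O)OC)c2)cc1` likewise gives only a limit in this assay, > 1000 nM. The step that the two limits leave unreadable from compound 1 to compound 2 cannot be read, since both values sit at the same limit (the limit of > 1000 nM in this assay, at which 2 of the 2 values shown sit). Compound 3 `COC(=O)/C=C/c1cccc(N(Cc2ccc(/C=C/c3cccc(Cl)c3)cc2)C(=O)C2CCCCC2)c1` differs from compound 2 by 3-chlorophenyl in place of ethoxycarbonyl on a double-bonded chain carbon bound to a double-bonded chain carbon. Among the compounds with values here, no measured step bears on this change, and compound 2 itself stands only at a limit, so no direction beyond the scatter can be expected. Compound 3 is therefore estimated at 1500 nM, between 300 nM and 10000 nM, an expected step that the limit leaves unreadable from compound 2 to compound 3.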

Compound 3, half-maximal effective concentration: 165 nM
Estimate against measurement, compound 3: 9.1-fold (0.96 log units) above; measured number outside the range, below it.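

In this assay there is an at least 6.0-fold lower number from compound 2 to compound 3 (0.78 log units; beyond the scatter), with 2-(3-chlorophenyl)ethenyl in place of 2-(ethoxycarbonyl)ethenyl, and an at least 6.0-fold lower number from compound 1 to compound 3 (0.78 log units; beyond the scatter), with the same group in place of bromo. This position, where neither earlier group gave a readable number, can therefore carry a group that does. Both steps give only a minimum size, because their starting compounds sit at a limit: the limit of > 1000 nM in this assay, at which 2 of the 3 values shown sit.

The compounds shown do not separate the roles of the ethenyl link, the ring and its chlorine. As far as these compounds go, whether an unsubstituted phenyl or a carboxylic acid at this place would give a readable number also stays open.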